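The compounds below may be only part of what the source reports. "The series", "measured", "known", "first", "only" and "open" are said of these compounds alone.

Three members of this set have been run through an ADME assay (liver) for metabolic stability, with Liver microsome (Homo sapiens) as the target, using microsomes and NADPH, with a stated time of 30 min, tested at 1 uM; a lower number here means slower removal, a higher number faster removal of the compound. Compound 1 `Cn1cc(-c2cc(C(O)(C(F)(F)F)C(F)(F)F)cnc2N2CCN(S(=O)(=O)c3ccc(N)nc3)CC2)cn1` gives 19 mL.min-1.g-1 in this assay, and compound 3 `CS(=O)(=O)c1ccc(-c2cc(C(O)(C(F)(F)F)C(F)(F)F)cnc2N2CCN(S(=O)(=O)c3ccc(N)nc3)CC2)cc1` gives 32 mL.min-1.g-1. For compound 2 `Nc1ccc(S(=O)(=O)N2CCN(c3ncc(C(O)(C(F)(F)F)C(F)(F)F)cc3-c3ccoc3)CC2)cn1` the assay returns only a limit, < 14 mL.min-1.g-1, which is the limit of < 14 mL.min-1.g-1 in this assay, at which 1 of the 3 values shown sits. Compound 2 is thus known only as a bound rather than as a number; its separation from compound 3 lies beyond the scatter, while its gap to compound 1 stays within it. The step of an at least 2.2-fold higher number from compound 2 to compound 3 (0.35 log units; beyond the scatter) is the one most closely tied to the present question, since it too starts from compound 2; the steps of a 1.7-fold higher number from compound 1 to compound 3 (0.23 log units; within the scatter) and an at least 1.3-fold lower number from compound 1 to compound 2 (0.13 log units; that floor lies within the scatter) both remain within the scatter. Compound 4 `Nc1ccc(S(=O)(=O)N2CCN(c3ncc(C(O)(C(F)(F)F)C(F)(F)F)cc3-c3ccc4sccc4c3)CC2)cn1` is the compound still to be measured. It differs from compound 2 in a single place: 1-benzothiophen-5-yl in place of furan-3-yl on an aromatic carbon. As in the step to compound 3, furan-3-yl gives way to a larger group, so the change is expected to push the number in this assay upward, likely by somewhat more than the measured floor of that step. Compound 4 is therefore expected to show an at least 2.8-fold higher number from compound 2 to compound 4 (0.45 log units; beyond the scatter). The value of compound 4 in this assay is estimated at about 40 mL.min-1.g-1, within a range from 18 mL.min-1.g-1 to 90 mL.min-1.g-1.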

Compound 4, intrinsic clearance in microsomes: 48 mL.min-1.g-1
Estimate against measurement, compound 4: 1.2-fold (0.08 log units) below, within the range that was stated.
By their numbers in this assay, from the lowest: compounds 1, 3 and 4 (each within the scatter of the next, the first and the last beyond it). At a limit, below all of these: compound 2.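

Replacing furan-3-yl with 1-benzothiophen-5-yl at this position gives a clear rise in this assay, an at least 3.4-fold higher number from compound 2 to compound 4 (0.53 log units; beyond the scatter), and shows that this aromatic carbon can carry a group that lifts the number well clear of compound 2. It also gives the first step from the 1-methyl-1H-pyrazol-4-yl group that leaves the scatter, a 2.5-fold higher number from compound 1 to compound 4 (0.40 log units; beyond the scatter), whereas the comparison with 4-(methylsulfonyl)phenyl does not separate the two groups, a 1.5-fold higher number from compound 3 to compound 4 (0.18 log units; within the scatter). Compound 2 remains known only as a limit, so the step from it is a floor and its true size is not known: the limit of < 14 mL.min-1.g-1 in this assay, at which 1 of the 4 values shown sits.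

The change from furan-3-yl to 1-benzothiophen-5-yl adds a six-membered aromatic ring of carbon only and exchanges oxygen for sulfur in one move, so the compounds shown cannot tell which of the two goes with the rise; a thiophen-3-yl or a 1-benzofuran-5-yl group would divide them. The shared core also stays fixed throughout, leaving open whether the same steps would appear on any other core, or with an amine or a carboxylic acid on the aromatic group.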